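Swapping the Amine Substituent on the Shared Core

This account rests on a few compounds, and the source may have more. Where it says the series, first, only, none or still open, it means among the compounds named here.

Of the compounds shown here, three with one shared core have been tested in a functional assay on HL-60 cells (Homo sapiens) for antiproliferative activity, with a stated time of 24 h; on this read-out lower numbers stand for stronger inhibition and higher numbers for weaker inhibition. Compound 1 `N#Cc1ccccc1CN1CCc2c(sc(NC(=O)c3ccccc3Cl)c2C(N)=O)C1` gives 10400 nM, compound 2 `Cc1ccc(C(=O)Nc2sc3c(c2C(N)=O)CCN(Cc2ccc(Cl)cc2Cl)C3)cc1` gives 19900 nM and compound 3 `NC(=O)c1c(NC(=O)c2ccccc2F)sc2c1CCN(Cc1cccc(Cl)c1)C2` gives 19800 nM. Compound 1 has the lowest of the three numbers, yet both of the others lie within the usual scatter of it, so no order among the three can be read from these values. Compound 4 `COc1ccccc1NC(=S)N1CCc2c(sc(NC(=O)c3ccccc3Cl)c2C(N)=O)C1` has not been measured. It differs from compound 1 in one place: a group of 11 heavy atoms (8 carbon, 1 nitrogen, 1 oxygen, 1 sulfur; one six-membered aromatic ring of carbon only) in place of a group of 9 heavy atoms (8 carbon, 1 nitrogen; one six-membered aromatic ring of carbon only), on an amine nitrogen in a ring. Among the compounds with values here, no measured pair shows what a change of this kind does, so any step is expected to be small, in either direction, and quite possibly not beyond the scatter. Compound 4 is expected to give 9000 nM, between 2500 nM and 32000 nM. That estimate for compound 4 amounts to an expected step of a 1.2-fold lower number from compound 1 to compound 4 (0.06 log units; within the scatter).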

Compound 4, half-maximal inhibitory concentration: 40900 nM
Beside the measured number, compound 4's estimate is 4.5-fold (0.66 log units) below it; the measured number lies above the stated range.
By their numbers in this assay, from the lowest: compounds 1, 3 and 2 (each within the scatter of the next); then compound 4.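

The amine nitrogen in the ring of the shared core is not indifferent to what it carries: in this assay, replacing 2-cyanobenzyl with the larger group containing oxygen and sulfur gives a 3.9-fold higher number from compound 1 to compound 4 (0.59 log units; beyond the scatter) for this change. Within the data shown here, this is the first single-place step available, and it goes towards weaker inhibition. Nothing measured here explains the step.

The whole group changes at once, so its parts cannot be judged separately. As far as these compounds go, how a plain benzyl group or a urea, with oxygen in place of the sulfur, would fare on this nitrogen remains open.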